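The source may hold more compounds than are shown below. What is called first, only, known or untested is meant among the compounds shown, and "the series" means these compounds.

Within the data shown here, in a functional assay on HCT-116 cells (Homo sapiens) for antiproliferative activity, read by MTT assay, with a stated time of 72 h (a lower number here means a stronger inhibitor, a higher number a weaker inhibitor), compound 1 `Cn1cc(-c2nn(Cc3ccc(C(=O)NC4CCCC4)cc3)c(=O)c3ccccc23)cn1` gives 14300 nM, the lower of the two numbers measured so far. Compound 2 `Cn1cc(-c2nn(Cc3ccc(C(=O)NC4CC(C)(C)N([O])C(C)(C)C4)cc3)c(=O)c3ccccc23)cn1` gives 50500 nM. That difference, a 3.5-fold higher number from compound 1 to compound 2 (0.55 log units; beyond the scatter), comes from a change on the amide-type nitrogen. Compound 3 `Cc1noc(C)c1-c1nn(Cc2ccc(C(=O)NC3CCCC3)cc2)c(=O)c2ccccc12` keeps that part of compound 1 and changes another part of the molecule: 3,5-dimethyl-1,2-oxazol-4-yl in place of 1-methyl-1H-pyrazol-4-yl on an aromatic carbon. In short, 3,5-dimethyl-1,2-oxazol-4-yl stands in place of 1-methyl-1H-pyrazol-4-yl on an aromatic carbon. Among the measured compounds shown here, no measured step covers this exchange, and the step to compound 2 a 3.5-fold higher number from compound 1 to compound 2 (0.55 log units; beyond the scatter) offers only a rough guide to size, from elsewhere in the molecule. The data give no direction, and a small change is expected, with the estimate being a 1.2-fold lower number from compound 1 to compound 3 (0.08 log units; within the scatter). For compound 3, the expected value in this assay is 12000 nM, with an estimated range of 4000 nM to 35000 nM.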

Compound 3, half-maximal inhibitory concentration: > 100000 nM
Compound 3: no number, only a limit (the forecaster's own chance of this, stated with the estimate: 10%); middle value at least 8.3-fold (0.92 log units) from the limit.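

Compound 3 carries a limit of the assay rather than a number in this assay: the limit of > 100000 nM in this assay, at which 1 of the 3 values shown sits.

Even with only a limit, the exchange reads as an at least 6.9-fold higher number from compound 1 to compound 3 (0.84 log units; beyond the scatter). Both groups are five-membered aromatic rings with equal counts of hetero atoms, hydrogen-bond donors and hydrogen-bond acceptors, yet the result differs beyond the scatter, so the number responds to the group on this aromatic carbon and not only to the group on the amide-type nitrogen.

The 3,5-dimethyl-1,2-oxazol-4-yl group differs from 1-methyl-1H-pyrazol-4-yl in both its ring atoms and its methyl groups, and these compounds cannot separate the two. Going by these compounds, whether a simple phenyl ring or an amine at this position would give a lower or a higher number remains open.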